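Shorter Alkenyl Chain on a Lactam Core

The compounds below may be only part of what the source reports. "The series", "measured", "known", "first", "only" and "open" are said of these compounds alone.

Measured so far:
Compound 1, `C=CCCCC1(CCCC=C)CN([Si](C)(C)C(C)(C)C)C1=O`, 25.2%
Compound 2, `C=CCCC1CN([Si](C)(C)C(C)(C)C)C1=O`, 49.5%
Compound 3, `C=CCCCC1CN([Si](C)(C)C(C)(C)C)C1=O`, 76.9%

In an assay for inhibition of Fatty-acid amide hydrolase 1 (Homo sapiens), tested at 1 mM (a lower number here means less inhibition, a higher number more inhibition at the concentration tested (going by the name of the read-out)), compound 3 stands highest of the three; compound 2 is nearest with a lower number, and compound 1 furthest.

Compound 4, `C=CCC1CN([Si](C)(C)C(C)(C)C)C1=O`, is not yet measured. The change from compound 3 to compound 4 is vinyl in place of but-3-en-1-yl on a saturated chain carbon bound to a saturated ring carbon. Stated one bond further out, pent-4-en-1-yl gives way to allyl, so the chain on the ring carbon loses two carbons.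

For the measured compounds named here, two measured steps bear on this. The step of a number 27.4 percentage points higher from compound 2 to compound 3 (beyond the scatter) shows that adding one carbon to that same chain raised the number by a modest amount in this assay. The step of a number 51.7 percentage points higher from compound 1 to compound 3 (beyond the scatter), which removes a whole second chain, is a different kind of change and bears less directly. Since compound 4 carries a chain shorter than that of compound 2, a step downward beyond the scatter is expected, plausibly somewhat larger than the step from compound 2 to compound 3.

Compound 4 is therefore expected to give about 30%, within 10% to 52%, an estimated step of a number 46.9 percentage points lower from compound 3 to compound 4 (beyond the scatter).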

Compound 4, a percentage reported as inhibition, at one concentration (the size of the read-out at that concentration, not a potency): 43.6%
The estimate for compound 4 lay 13.6 percentage points below the measured number; measured number inside the range.
By their numbers in this assay, from the lowest: compound 1; then compounds 4 and 2 (each within the scatter of the next); then compound 3.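

Shortening the chain from pent-4-en-1-yl to allyl in this assay gives a number 33.3 percentage points lower from compound 3 to compound 4 (beyond the scatter), whereas the change of vinyl in place of allyl on the same saturated chain carbon gives a number 5.9 percentage points lower from compound 2 to compound 4 (within the scatter). Compound 2 and compound 4 therefore cannot be told apart in this assay, so the three monosubstituted compounds do not form an even ladder in which each added carbon brings a similar gain; only compound 3, with the pent-4-en-1-yl chain, stands clear of the other two. No measurement here explains why this one chain length stands apart from the two shorter ones.

The compounds shown leave open whether a longer chain, such as hex-5-en-1-yl, would keep, raise or lower the number seen for compound 3, so the upper limit of useful chain length at this position remains unknown. They also leave open whether the terminal double bond matters, which a saturated pentyl chain could test, and how a chain ending in an amine or a carboxylic acid would compare.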